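Swapping Butyl for Cyclopentyl: An Expected Antiproliferative Step

The source may report more compounds than this note shows. Statements on the series, on what has been measured and on what is new or still open speak of the compounds shown alone.

Of the compounds shown here, three sharing one core have been tested in a functional assay on NCI-H460 cells (Homo sapiens) for antiproliferative activity, read by CCK-8 assay, with a stated time of 72 h, tested at 8 uM; a lower number here means a weaker effect, a higher number a stronger effect of the compound at the concentration tested. Compound 2 `CCCCn1cnc2c(Nc3ccccc3)nc(NCOCc3ccc(C(=O)Nc4ccccc4N)cc3)nc21` gives 51.3%. Compound 1 `Nc1ccccc1NC(=O)c1ccc(COCNc2nc(Nc3ccccc3)c3ncn(C4CCCC4)c3n2)cc1` carries cyclopentyl in place of butyl on an aromatic nitrogen, and in this assay compound 1 gives 56.1%; the step is a number 4.8 percentage points higher from compound 2 to compound 1 (within the scatter). Compound 3 `CCCCn1cnc2c(Nc3cccc(Cl)c3)nc(NCOCc3ccc(C(=O)Nc4ccccc4N)cc3)nc21` instead carries chloro in place of hydrogen on an aromatic carbon, and in this assay compound 3 gives 62%, a step of a number 10.7 percentage points higher from compound 2 to compound 3 (beyond the scatter). Compound 4 `Nc1ccccc1NC(=O)c1ccc(COCNc2nc(Nc3cccc(Cl)c3)c3ncn(C4CCCC4)c3n2)cc1` is not yet measured; it differs from compound 3 by cyclopentyl in place of butyl on an aromatic nitrogen, the same change that turns compound 2 into compound 1. On the strength of a number 4.8 percentage points higher from compound 2 to compound 1 (within the scatter), a step of similar size is expected for compound 4, namely a number 4 percentage points higher from compound 3 to compound 4 (within the scatter). Compound 4 is therefore estimated at 66%, with the number most likely falling between 55% and 76%.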

Compound 4, a percentage reported as inhibition, at one concentration (the size of the read-out at that concentration, not a potency): 49.2%
The estimate for compound 4 lay 16.8 percentage points above the measured number, and the stated range ends above it.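

In this assay, the swap of butyl for cyclopentyl does not carry over unchanged once chloro is present; the step is a number 12.8 percentage points lower from compound 3 to compound 4 (beyond the scatter), and it differs from the earlier step: the same change on two cores in this assay, a number 4.8 percentage points higher (within the scatter) from compound 2 to compound 1 and a number 12.8 percentage points lower (beyond the scatter) from compound 3 to compound 4, 17.6 percentage points apart, beyond the scatter of two such steps. Seen from the other change, adding chloro to the cyclopentyl compound gives a number 6.9 percentage points lower from compound 1 to compound 4 (within the scatter), which also stands apart from the step seen with butyl: the same change on two cores in this assay, a number 10.7 percentage points higher (beyond the scatter) from compound 2 to compound 3 and a number 6.9 percentage points lower (within the scatter) from compound 1 to compound 4, 17.6 percentage points apart, beyond the scatter of two such steps. So in these four compounds the two changes do not simply add up, but this rests on a single set of four and does not show why.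

The compounds shown leave open how a longer chain or a cyclohexyl group on that aromatic nitrogen would behave with and without chloro. Going by these compounds, it is also open whether fluoro in place of chloro would give the same result.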